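Pyridin-2-yl in place of 4-methoxyphenyl: compound 4

A few compounds are considered here, and "the series" means these few. Any claim that something is new, unique, unknown or untested is made for them only; others in the source may bear on it.

Compound 2 `COc1ccc(-c2cn(C[C@H]3c4c(ccc(O)c4C)[C@@H]4CC[C@@]5(C)C[C@]43CC5=O)nn2)cc1` is known in a functional assay on MCF7 cells (Homo sapiens) for cytotoxicity, read by MTT assay, with a stated time of 4 days (on this read-out lower numbers stand for stronger inhibition and higher numbers for weaker inhibition), only as a limit: compound 2 gives > 20000 nM, which is a limit of the assay and not a number. Compound 1 `C=C1C[C@]23C[C@@]1(O)CC[C@H]2c1ccc(OS(=O)(=O)c2ccc(C)cc2)c(C)c1[C@@H]3Cn1cc(-c2ccc(Br)cc2)nn1` gives > 20000 nM in this assay, again a limit. Compound 3 `C=C1C[C@]23C[C@@]1(O)CC[C@H]2c1ccc(OS(=O)(=O)c2ccc(C)cc2)c(C)c1[C@@H]3Cn1cc(-c2ccc(C)cc2)nn1` gives > 20000 nM in this assay, also a limit. For the measured compounds named here, the only single-point step among the measured compounds, a step that the two limits leave unreadable from compound 1 to compound 3, cannot be read because of the limit of > 20000 nM in this assay, at which 3 of the 3 values shown sit. Compound 4 `Cc1c(O)ccc2c1[C@H](Cn1cc(-c3ccccn3)nn1)[C@@]13CC(=O)[C@@](C)(CC[C@@H]21)C3` differs from compound 2 by pyridin-2-yl in place of 4-methoxyphenyl on an aromatic carbon. Going by the values given here, no measured step bears on this change, since every value shown sits at the limit. Compound 4 is therefore expected to remain at or past the limit, estimated at 30000 nM within a range of 10000 nM to 100000 nM. The expected step that the limit leaves unreadable from compound 2 to compound 4 is thus one the assay is unlikely to resolve.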

Compound 4, half-maximal inhibitory concentration: > 20000 nM
Compound 4: no number, only a limit; the forecaster's own chance of this, stated with the estimate: 85%; the middle value is on the limit's open side.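

No new step can be read between compound 2 and compound 4, as neither gives a number in this assay: the limit of > 20000 nM in this assay, at which 4 of the 4 values shown sit.

The compounds shown leave open whether any group at this place gives a measurable value in this assay.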